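This account rests on a few compounds, and the source may have more. Where it says the series, first, only, none or still open, it means among the compounds named here.

Among the measured compounds shown here, in an ADME assay on microsomes from liver (Homo sapiens) for metabolic stability, using NADPH, with a stated time of 10 min (a higher number here means that more of the compound is left, a lower number that less of the compound is left), compound 1 `CN(C[C@H]1Cc2c(cccc2N2C[C@H]3CNC[C@H]3C2)CN1)[C@H]1CCCc2cccnc21` gives 86.7%, the higher of the two numbers so far, while compound 2 `CN(C)[C@H]1CCN(c2cccc3c2C[C@H](CN(C)[C@H]2CCCc4cccnc42)NC3)C1` gives 67.5%. Compound 3 `CN1CC[C@H]2CN(c3cccc4c3C[C@H](CN(C)[C@H]3CCCc5cccnc53)NC4)C[C@H]21` differs from compound 1 by a group of 9 heavy atoms (7 carbon, 2 nitrogen; 2 five-membered non-aromatic rings with 1 hetero atom each) in place of a group of 8 heavy atoms (6 carbon, 2 nitrogen; 2 five-membered non-aromatic rings with 1 hetero atom each), on an aromatic carbon, on an aromatic carbon of the shared core. For the measured compounds named here, only one measured step bears on this change: a number 19.2 percentage points lower from compound 1 to compound 2 (beyond the scatter), which involves a different group at the same place. With that single step as a guide, a fall of similar or somewhat smaller size is expected, the estimated step being a number 14.7 percentage points lower from compound 1 to compound 3 (beyond the scatter). For compound 3 the estimated value is 72%, with an expected range from 52% to 88%.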

Compound 3, percent of the compound remaining: 87.3%
Estimate against measurement, compound 3: 15.3 percentage points below; the range from low to high includes it.
By their numbers in this assay, from the lowest: compound 2; then compounds 1 and 3 (each within the scatter of the next).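

At this aromatic carbon of the shared core, in this assay, exchanging the group with 1 hydrogen-bond donor for the group with 0 gives a number 0.6 percentage points higher from compound 1 to compound 3 (within the scatter) and so leaves the percentage remaining unchanged. The fall seen with compound 2 does not extend to this larger group, as there is a number 19.8 percentage points higher from compound 2 to compound 3 (beyond the scatter) and both groups with 2 five-membered rings stand clear of compound 2.

As far as these compounds go, whether a piperazine or an open-chain amine at this place would fare alike remains open. No measurement at hand accounts for these steps.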